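Swapping a methyl for a pyrazinyl on a piperidine tail

This account rests on a few compounds, and the source may have more. Where it says the series, first, only, none or still open, it means among the compounds named here.

Three compounds share one core and differ only in the group carried by the chain on the aromatic nitrogen. Compound 1 `Cc1cnc(-c2ccccc2C(C)C)nc1NCc1cccnc1` gives 1300 nM in an assay on a protein complex for inhibition of ubiquitin carboxyl-terminal hydrolase 1/WD repeat-containing protein 48 (Homo sapiens), read by fluorescence; a lower number here means a stronger inhibitor, a higher number a weaker inhibitor. Compound 2 `Cc1cnc(-c2ccccc2C(C)C)nc1NCc1cccs1` gives 270 nM in this assay, and the step of a 4.8-fold lower number from compound 1 to compound 2 (0.68 log units; beyond the scatter) is the only one measured so far. Compound 3 `Cc1cnc(-c2ccccc2C(C)C)nc1NCC1CCN(C)CC1`, with a saturated ring in place of the aromatic ones, is reported as "not active" (no number reported) in this assay, so no number marks where it stands; it can only be said to lie beyond the reach of the measurement.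

Compound 4 `Cc1cnc(-c2ccccc2C(C)C)nc1NCC1CCN(c2cnccn2)CC1` is the next candidate. It differs from compound 3 in one place: pyrazin-2-yl in place of methyl on an amine nitrogen in a ring. For the measured compounds named here, no measured step touches this amine nitrogen in a ring, and the step from compound 1 to compound 2 concerns a different part of the molecule, so it does not tell the direction here. With compound 3 giving no number, the expectation for compound 4 rests on little, and it is estimated only as 5000 nM, within 800 nM to 30000 nM.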

Compound 4, half-maximal inhibitory concentration: 140 nM
Compound 4: middle estimate off by 36-fold (1.55 log units), on the high side; measured number outside the range, below it.
By their numbers in this assay, from the lowest: compounds 4 and 2 (each within the scatter of the next); then compound 1.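

For the compounds shown here, compound 3 has no number in this assay and compound 4 gives 140 nM there, so no step between them can be read. Nothing available explains this result. Still open, on these data alone, is whether groups other than pyrazin-2-yl on that amine nitrogen would give similar numbers.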